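This account rests on a few compounds, and the source may have more. Where it says the series, first, only, none or still open, it means among the compounds named here.

In a physicochemical assay for solubility, at pH 7.4 (on this read-out higher numbers stand for higher solubility and lower numbers for lower solubility), three compounds have been measured:

- Compound 1 `CC(C)OC(=O)C1CN(C(=O)c2ccc(F)c(F)c2)CC(C)(C)c2cc(C#N)[nH]c21`: 31 ug/mL
- Compound 2 `CC(C)OC(=O)C1CN(C(=O)C2CCCCC2)CC(C)(C)c2cc(C#N)[nH]c21`: > 100 ug/mL, which is a limit of the assay and not a number
- Compound 3 `CC(C)OC(=O)C1CN(C(=O)c2ccc(C#N)cc2)CC(C)(C)c2cc(C#N)[nH]c21`: 21 ug/mL

Compound 3 shares its place with compound 1 at the low end of the numbers shown. The step between these two is a 1.5-fold lower number from compound 1 to compound 3 (0.17 log units; within the scatter). The cyclohexyl amide stands clearly apart, with an at least 4.7-fold lower number from compound 2 to compound 3 (0.67 log units; beyond the scatter).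

Compound 4 `CC(C)OC(=O)C1CN(C(=O)c2ccc(Cl)cc2)CC(C)(C)c2cc(C#N)[nH]c21` keeps the shared core and the carbonyl of compound 3 and alters only the phenyl substituent: chloro in place of cyano on an aromatic carbon. The change is thus chloro in place of cyano on an aromatic carbon, para to a large group.

The closest guide is the exchange of one substituted phenyl for another, a 1.5-fold lower number from compound 1 to compound 3 (0.17 log units; within the scatter), which stayed within the scatter. The larger step, an at least 3.2-fold higher number from compound 1 to compound 2 (0.50 log units; beyond the scatter), removes the aromatic ring altogether, and compound 4 keeps that ring, so this step bears on it only weakly. Among the measured compounds shown here, no measured step covers chloro itself.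

In this assay, no change beyond the scatter is therefore expected, and the expected move is a 1.1-fold lower number from compound 3 to compound 4 (0.02 log units; within the scatter). Compound 4 is estimated at 20 ug/mL, with an expected range of 8 ug/mL to 45 ug/mL.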

Compound 4, solubility: 5 ug/mL
The estimate for compound 4 lay 4.0-fold (0.60 log units) above the measured number, outside the stated range (below it).
By their numbers in this assay, from the lowest: compound 4; then compounds 3 and 1 (each within the scatter of the next). At a limit, above all of these: compound 2.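

In this assay, the substituent on an aromatic carbon, para to a large group, proves able to move the number on its own: a 4.2-fold lower number from compound 3 to compound 4 (0.62 log units; beyond the scatter), a step beyond the scatter, whereas the earlier exchange of one substituted phenyl for another had stayed within it. The aromatic amides shown therefore no longer sit together, with a 6.2-fold lower number from compound 1 to compound 4 (0.79 log units; beyond the scatter), and compound 4 now lies at the low end, its steps to all the others printed as beyond the scatter. Compound 2 holds a limit and not a number, so the widest step, an at least 20-fold lower number from compound 2 to compound 4 (1.30 log units; beyond the scatter), marks only a bound on that gap and not its true size: the limit of > 100 ug/mL in this assay, at which 1 of the 4 values shown sits.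

The compounds shown leave open whether the drop belongs to chloro itself or to the departure of cyano, and so whether an unsubstituted phenyl would read with compound 3 or with compound 4. They also leave open how a methoxy group or an amine would read at this same place, and whether a piperidine on the carbonyl carbon would stay as close to compound 2 as its saturated ring might suggest.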